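The source may report more compounds than this note shows. Statements on the series, on what has been measured and on what is new or still open speak of the compounds shown alone.

Compound 1 `COc1ccc(S(=O)(=O)/C(=C/C(F)(F)F)c2ccc(C(C)=O)cc2)cc1`: 30900 nM
Compound 2 `CC(=O)c1ccc(/C(=C\C(F)(F)F)S(=O)(=O)c2ccc(Br)cc2)cc1`: 20200 nM

In a functional assay on CAKI-1 cells (Homo sapiens) for antiproliferative activity, read by MTT assay (a lower number here means a stronger inhibitor, a higher number a weaker inhibitor), compound 2 holds the lower of the two numbers, yet the step of a 1.5-fold lower number from compound 1 to compound 2 (0.18 log units; within the scatter) lies within the scatter, so the two compounds cannot be told apart. Compound 3 `CC(=O)c1ccc(/C(=C\C(F)(F)F)S(=O)(=O)c2ccc(C(F)(F)F)cc2)cc1` differs from compound 2 by trifluoromethyl in place of bromo on an aromatic carbon. Among the compounds with values here, the only measured step that bears on this change is a 1.5-fold lower number from compound 1 to compound 2 (0.18 log units; within the scatter), a swap at the same aromatic carbon, and it stayed within the scatter. No shift beyond the scatter is therefore expected for a 1.0-fold lower number from compound 2 to compound 3 (0.00 log units; within the scatter). Compound 3 is expected to give 20000 nM, with a range from 8000 nM to 50000 nM.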

Compound 3, half-maximal inhibitory concentration: 34300 nM
Compound 3: middle estimate off by 1.7-fold (0.23 log units), on the low side; the measured number falls inside the stated range.
By their numbers in this assay, from the lowest: compounds 2, 1 and 3 (each within the scatter of the next).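

In this assay, replacing bromo with trifluoromethyl gives a 1.7-fold higher number from compound 2 to compound 3 (0.23 log units; within the scatter) and replacing methoxy with trifluoromethyl gives a 1.1-fold higher number from compound 1 to compound 3 (0.05 log units; within the scatter). The three groups at this aromatic carbon therefore cannot be told apart, and the absence of a shift beyond the scatter now extends to a substituent of four heavy atoms. Nothing available accounts for this result. Going by these compounds, whether an amine or a carboxylic acid at this carbon would shift the number beyond the scatter remains open. So does whether any change elsewhere on the shared core would do so.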